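This account rests on a few compounds, and the source may have more. Where it says the series, first, only, none or still open, it means among the compounds named here.

Working notes on the series. Three compounds have so far been taken into a functional assay on Ramos cells (Homo sapiens) for antiproliferative activity, read by CCK-8 assay, with a stated time of 24 h; a lower number here means a stronger inhibitor, a higher number a weaker inhibitor. Compound 1 `C=CC(=O)Nc1cccc(Nc2nc(Cl)nc(Nc3ccc(OCCOC)cc3)n2)c1` has in this assay "not determined" (no result reported) and so offers no anchor. Compound 2 `CC#CC(=O)Nc1cccc(Nc2ncnc(Nc3ccc(C(=O)N4CCCCC4)cc3)n2)c1` gives in this assay 24400 nM. Compound 3 `C=CC(=O)Nc1cccc(Nc2nc(Cl)nc(Nc3ccc(Oc4ccccc4)cc3)n2)c1` gives in this assay 12300 nM, the lower of the two numbers; its nearest neighbour is compound 2, and the gap between the two values lies within the usual scatter, so no order between compound 2 and compound 3 can be claimed. Both numbers sit in the weak range.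

Compound 4 `C=CC(=O)Nc1cccc(Nc2nc(N)nc(Nc3ccc(Oc4ccccc4)cc3)n2)c1` is the next entry and differs from compound 3 in one place: amino in place of chloro on an aromatic carbon. Among the measured compounds shown here, no step between measured compounds touches this position, so there is no measured size to carry over. The change swaps one heavy atom for another and leaves the remainder of the molecule untouched. The expectation for this assay is therefore a step of modest size at most, and possibly none beyond the scatter, with no firm direction. Compound 4 is expected in this assay near 9000 nM, within a range from 2500 nM to 32000 nM. The step from compound 3 to compound 4 is accordingly estimated at a 1.4-fold lower number from compound 3 to compound 4 (0.14 log units; within the scatter).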

Compound 4, half-maximal inhibitory concentration: 20000 nM
Beside the measured number, compound 4's estimate is 2.2-fold (0.35 log units) below it; measured number inside the range.
By their numbers in this assay, from the lowest: compounds 3, 4 and 2 (each within the scatter of the next).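

In this assay, among the compounds shown here, amino in place of chloro on an aromatic carbon, between two ring nitrogen atoms, gives a 1.6-fold higher number from compound 3 to compound 4 (0.21 log units; within the scatter), the first measured step at this position. Exchanging a group with 0 hydrogen-bond donors and 0 hydrogen-bond acceptors for one with 1 of each therefore yields a step that stays within the scatter, so neither group can be ranked over the other here, and both compounds remain in the weak range. No available evidence bears on this result, and the data offer no explanation for it.

As far as these compounds go, it remains open whether this position responds to any group with more than one heavy atom, such as methoxy or dimethylamino, as only chloro and amino are compared here with the rest of the molecule held constant. From the compounds shown here alone, it is also open whether the same exchange would give a similar step with a group other than phenoxy on the far aromatic ring, such as a longer ether chain or a piperidine amide.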